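The source may hold more compounds than are shown below. What is called first, only, known or untested is meant among the compounds shown, and "the series" means these compounds.

Compound 3 `Cc1ncnc2c1c(-c1cccs1)cn2[C@@H]1O[C@H](CO)[C@@H](O)[C@H]1O` carries a methyl on the shared core. In a functional assay on CCRF-CEM cells (Homo sapiens), read by MTT assay, with a stated time of 72 h (on this read-out lower numbers stand for stronger inhibition and higher numbers for weaker inhibition), compound 3 gives > 20000 nM, which is a limit of the assay rather than a number. Its methoxy counterpart, compound 2 `COc1ncnc2c1c(-c1cccs1)cn2[C@@H]1O[C@H](CO)[C@@H](O)[C@H]1O`, gives 90 nM in this assay. Going by the values given here, the step of an at least 220-fold higher number from compound 2 to compound 3 (2.34 log units; beyond the scatter) is the only measured step at this place, and it rests on (the limit of > 20000 nM in this assay, at which 1 of the 3 values shown sits). Compound 1 `CN(C)c1ncnc2c1c(-c1ccoc1)cn2[C@@H]1O[C@H](CO)[C@@H](O)[C@H]1O` bears a dimethylamino together with a furan and gives 13300 nM in this assay. Compound 4 `CN(C)c1ncnc2c1c(-c1cccs1)cn2[C@@H]1O[C@H](CO)[C@@H](O)[C@H]1O` takes the change (dimethylamino in place of methyl on an aromatic carbon). Among the compounds with values here, no measured step pairs a dimethylamino with a thiophene, so the expectation leans on compound 1 and on the limit of compound 3. Compound 4 is therefore expected to give 4000 nM, between 500 nM and 20000 nM. That expectation amounts to a step of an at least 5.0-fold lower number from compound 3 to compound 4 (0.69 log units; beyond the scatter).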

Compound 4, half-maximal inhibitory concentration: > 20000 nM
Compound 4: only a limit was reported; the forecaster's own chance of this, stated with the estimate: 20%; middle value at least 5.0-fold (0.69 log units) away from the limit.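

Going by these compounds alone, with the thiophene kept, dimethylamino joins methyl at the assay limit, leaving methoxy as the only one of the three groups at this position with a readable value: this assay shows an at least 220-fold higher number from compound 2 to compound 4 (2.34 log units; beyond the scatter). The change of ring gives an at least 1.5-fold higher number from compound 1 to compound 4 (0.17 log units; that floor lies within the scatter), so no effect of thiophene-2-yl over furan-3-yl can be claimed. The steps between limit values cannot be read, as compound 3 and compound 4 both sit at the limit: the limit of > 20000 nM in this assay, at which 2 of the 4 values shown sit.

From the compounds shown here alone, whether an ethoxy group or a primary amine at this position would give a readable value remains open.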